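The source may hold more compounds than are shown below. What is called first, only, known or untested is meant among the compounds shown, and "the series" means these compounds.

Compound 1 `CCCC(=O)N1CCC(NS(=O)(=O)c2ccc(NC(=O)C3CCCCC3)c3ccccc23)CC1`: in an in vitro functional assay on CHO/Galpha16 cells for antagonist activity at C-C chemokine receptor type 8 (Homo sapiens), read by FLIPR (on this read-out lower numbers stand for stronger inhibition and higher numbers for weaker inhibition), compound 1 gives 6.1 nM
Compound 2 `CCCC(=O)N1CCC(NS(=O)(=O)c2ccc(NC(=O)c3cccc(C)c3)c3ccccc23)CC1`: in this assay compound 2 gives 5.1 nM
Compound 3 `CCCC(=O)N1CCC(NS(=O)(=O)c2ccc(NC(=O)c3ccc(C(C)(C)C)cc3)c3ccccc23)CC1`: in this assay compound 3 gives 6.9 nM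

Compound 2 has the lowest of the three numbers, but its neighbours sit close: a 1.2-fold lower number from compound 1 to compound 2 (0.08 log units; within the scatter) and a 1.4-fold higher number from compound 2 to compound 3 (0.13 log units; within the scatter) are both within the scatter, as is a 1.1-fold higher number from compound 1 to compound 3 (0.05 log units; within the scatter). The three measured compounds therefore cannot be ranked against one another. Compound 4 `CCCC(=O)N1CCC(NS(=O)(=O)c2ccc(NC(=O)c3ccoc3)c3ccccc23)CC1` has not yet been measured. It differs from compound 2 in one place: furan-3-yl in place of 3-methylphenyl on a carbonyl carbon. The measured steps that bear on this change are those among compounds 1, 2 and 3, where a cyclohexyl, a 3-methylphenyl and a 4-(tert-butyl)phenyl on the same carbonyl carbon all gave numbers within the scatter of one another. Going by the values given here, compound 4 carries a smaller ring with one hetero atom, for which no measured step exists. On the evidence of the three steps, no change beyond the scatter in this assay is expected, though the estimate for compound 4 is left somewhat wider towards the higher side. Compound 4 is expected to give 10 nM in this assay, with a range from 4 nM to 30 nM, a step of a 2.0-fold higher number from compound 2 to compound 4 (0.29 log units; within the scatter).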

Compound 4, half-maximal inhibitory concentration: 1520 nM
Compound 4: the middle estimate sits 150-fold (2.18 log units) below what was measured, and the stated range ends below it.
By their numbers in this assay, from the lowest: compounds 2, 1 and 3 (each within the scatter of the next); then compound 4.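

At this position, on a carbonyl carbon whose other neighbour is an amide-type nitrogen, this assay turns out to be far from indifferent to the group carried: furan-3-yl gives a 300-fold higher number from compound 2 to compound 4 (2.47 log units; beyond the scatter) and a 220-fold higher number from compound 3 to compound 4 (2.34 log units; beyond the scatter) and also a 250-fold higher number from compound 1 to compound 4 (2.40 log units; beyond the scatter) as the steps from the three earlier groups. The agreement among cyclohexyl, 3-methylphenyl and 4-(tert-butyl)phenyl therefore does not extend to every ring at this place, and a single change here can separate compounds widely. Nothing measured here accounts for the loss.

The compounds shown do not tell whether the loss follows the ring oxygen, the five-membered ring or the smaller count of heavy atoms. A plain phenyl or a thiophen-3-yl on the same carbonyl carbon would bear on that question.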